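Anilino switch on two cores of a cyanopyrimidine series

The source may report more compounds than this note shows. Statements on the series, on what has been measured and on what is new or still open speak of the compounds shown alone.

Measured compounds:
compound 1 `COc1cc(-c2nc(SCc3cn(CC(=O)NC(=O)Nc4ccccn4)nn3)nc(Nc3ccc(C)cc3)c2C#N)cc(OC)c1OC`, 7030 nM
compound 2 `COc1cc(-c2nc(SCc3cn(CC(=O)NC(=O)Nc4ccccn4)nn3)nc(Nc3cccc(Cl)c3)c2C#N)cc(OC)c1OC`, 15400 nM
compound 3 `Cc1ccc(Nc2nc(SCc3cn(CC(=O)NC(=O)Nc4ccccn4)nn3)nc(-c3ccc(C)cc3)c2C#N)cc1`, 9890 nM

Compound 1, compound 2 and compound 3 were tested in a functional assay on MGC-803 cells (Homo sapiens) for inhibition, read by MTT assay, with a stated time of 72 h; on this read-out lower numbers stand for stronger inhibition and higher numbers for weaker inhibition. Compound 4 `Cc1ccc(-c2nc(SCc3cn(CC(=O)NC(=O)Nc4ccccn4)nn3)nc(Nc3cccc(Cl)c3)c2C#N)cc1` is the one not yet measured.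

The two cores differ as described by 4-methylphenyl in place of 3,4,5-trimethoxyphenyl on an aromatic carbon, a change that gave a 1.4-fold higher number from compound 1 to compound 3 (0.15 log units; within the scatter). On the core of compound 1, the change 3-chlorophenyl in place of 4-methylphenyl on a nitrogen on an aromatic ring gave a 2.2-fold higher number from compound 1 to compound 2 (0.34 log units; beyond the scatter).

Compound 4 carries the same change on the core of compound 3, namely (3-chlorophenyl in place of 4-methylphenyl on a nitrogen on an aromatic ring), and the surroundings of the place are the same in both cases. Only one earlier example of this change exists, so the expectation rests on a single pair and on the observation that the cores themselves sit close, as shown by a 1.4-fold higher number from compound 1 to compound 3 (0.15 log units; within the scatter). Compound 4 is therefore expected to move by about a 2.1-fold higher number from compound 3 to compound 4 (0.33 log units; beyond the scatter), beside the earlier step of a 2.2-fold higher number from compound 1 to compound 2 (0.34 log units; beyond the scatter). The estimate for compound 4 is 21000 nM, with a range from 9000 nM to 50000 nM.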

Compound 4, half-maximal inhibitory concentration: 7890 nM
Compound 4: middle estimate off by 2.7-fold (0.43 log units), on the high side, outside the stated range (below it).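

In this assay, 3-chlorophenyl in place of 4-methylphenyl on the core of compound 3 gave a 1.3-fold lower number from compound 3 to compound 4 (0.10 log units; within the scatter), so the rise seen on the core of compound 1 did not carry over: the same change on two cores in this assay, a 2.2-fold higher number (0.34 log units; beyond the scatter) from compound 1 to compound 2 and a 1.3-fold lower number (0.10 log units; within the scatter) from compound 3 to compound 4, 2.7-fold (0.44 log units) apart, beyond the scatter of two such steps. Read the other way, 4-methylphenyl in place of 3,4,5-trimethoxyphenyl gave a 2.0-fold lower number from compound 2 to compound 4 (0.29 log units; within the scatter), which also fails to match its earlier step: the same change on two cores in this assay, a 1.4-fold higher number (0.15 log units; within the scatter) from compound 1 to compound 3 and a 2.0-fold lower number (0.29 log units; within the scatter) from compound 2 to compound 4, 2.7-fold (0.44 log units) apart, beyond the scatter of two such steps. For the compounds shown here, in these four compounds, the outcome of the change on the nitrogen therefore differs with the core, but with only one pair per core this does not show why the two cores part or how general the difference is.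

The compounds shown leave open whether a fluorine atom or a methoxy group in place of the chlorine of the 3-chlorophenyl would follow the core of compound 1 or that of compound 3. They also leave open how the same change would behave on a third core.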